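The source may hold more compounds than are shown below. What is called first, only, known or untested is meant among the compounds shown, and "the series" means these compounds.

In an ADME assay on brain (Rattus norvegicus) for protein binding (a lower number here means a smaller unbound share, a higher number a larger unbound share of the compound), compound 1 `O=C1O[C@]2(CC[C@H](CNc3ccc(-c4ncccn4)cn3)CC2)CN1c1ccccn1` gives 0.035 as its reading. For compound 2 `O=C1O[C@]2(CC[C@H](CNc3ccc(-c4ccccc4F)nc3)CC2)CN1c1ccccn1` the entry is "not determined" (no result reported) and no number exists. Compound 3 `O=C1O[C@]2(CC[C@H](CNc3cnn(-c4ccccc4F)c3)CC2)CN1c1cccnn1` gives 0.031 as its reading, which lies within the scatter of compound 1. Compound 4 `O=C1O[C@]2(CC[C@H](CNc3cnn(-c4ccccc4F)c3)CC2)CN1c1ccnnc1` has the same atoms as compound 3, joined differently, with pyridazin-4-yl in place of pyridazin-3-yl on an amide-type nitrogen in a ring as the counted difference: pyridazin-4-yl in place of pyridazin-3-yl on an amide-type nitrogen in a ring. For the measured compounds named here, no step between measured compounds exists to guide this change, so nothing beyond the scatter is expected in this assay in either direction. The expected change is small, with a 1.3-fold higher number from compound 3 to compound 4 (0.11 log units; within the scatter) as the estimate. For compound 4 the estimated value is 0.04 within a range from 0.02 to 0.08 on this measure.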

Compound 4, unbound fraction: 0.044
The estimate for compound 4 lay 1.1-fold (0.04 log units) below the measured number, and the stated range covers the measured number.
By their numbers in this assay, from the lowest: compounds 3, 1 and 4 (each within the scatter of the next).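

In this assay, putting pyridazin-4-yl in place of pyridazin-3-yl on the amide-type nitrogen in a ring gives a 1.4-fold higher number from compound 3 to compound 4 (0.15 log units; within the scatter). This is the only step shown at this position, and it shows that this exchange of one ring for its isomer does not separate the two compounds on this measure. Nothing given here offers an explanation for the result. The compounds shown leave open whether a non-aromatic group on that nitrogen, such as a cyclopropyl or a methyl, would move the unbound fraction beyond the scatter.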